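Dichlorophenyl for fluorophenyl on the sulfur of compound 2

The source may hold more compounds than are shown below. What is called first, only, known or untested is meant among the compounds shown, and "the series" means these compounds.

Of the compounds shown here, three built on the same core have been tested in a functional assay on SK-OV-3 cells (Homo sapiens) for inhibition, read by sulforhodamine B assay, with a stated time of 48 h; on this read-out lower numbers stand for higher toxicity in this test and higher numbers for lower toxicity in this test. Compound 1, `Nc1cc(N)c2nc(-c3ccccc3)c(NCc3ccc(Cl)c(Cl)c3)nc2c1`, gives 69200 nM. Compound 2, `Nc1cc(N)c2nc(-c3ccccc3)c(Sc3ccc(F)cc3)nc2c1`, gives 63100 nM, and compound 3, `COc1cc(CNc2nc3cc(N)cc(N)c3nc2-c2ccccc2)cc(OC)c1OC`, gives 36300 nM. Compound 2 stands second highest of the three numbers; its nearest neighbour is compound 1 and its furthest is compound 3, and both gaps lie within the scatter of repeated runs, so no ordering among the three can be claimed.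

Compound 4, `Nc1cc(N)c2nc(-c3ccccc3)c(Sc3ccc(Cl)c(Cl)c3)nc2c1`, is not yet measured. It differs from compound 2 by 3,4-dichlorophenyl in place of 4-fluorophenyl on a sulfur. For the measured compounds named here, no step between two measured compounds isolates this change, so the expectation rests on the narrow spread of the three values. The step expected in this assay is a 1.1-fold lower number from compound 2 to compound 4 (0.06 log units; within the scatter), that is, none beyond the scatter. Compound 4 is therefore expected to give about 55000 nM, within a range from 25000 nM to 120000 nM.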

Compound 4, concentration lethal to 50% of the cells: < 100000 nM
Compound 4: only a limit was reported (the forecaster's own chance of this, stated with the estimate: 10%); the middle value does not contradict the limit.
By their numbers in this assay, from the lowest: compounds 3, 2 and 1 (each within the scatter of the next).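

In this assay, for the compounds shown here, compound 4 gives < 100000 nM as a limit and not a number, so no step from compound 2 to compound 4 can be read. Whether and how far 3,4-dichlorophenyl in place of 4-fluorophenyl on a sulfur shifts the number in this assay is left open by the compounds shown.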